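The compounds below may be only part of what the source reports. "The series", "measured", "known", "first", "only" and "open" are said of these compounds alone.

Measured compounds in this series:
- compound 1 `C=CCNc1n[n+]([O-])c2ccccc2[n+]1[O-]`: 25800 nM
- compound 2 `[O-][n+]1nc(NCc2ccccc2)[n+]([O-])c2ccccc21`: 2500 nM

In a functional assay on HL-60 cells (Homo sapiens) for cytotoxicity, read by MTT assay, with a stated time of 48 h (on this read-out lower numbers stand for stronger inhibition and higher numbers for weaker inhibition), compound 1 gives 25800 nM, the highest of the two numbers recorded; the nearest neighbour is compound 2, reached by a 10-fold lower number from compound 1 to compound 2 (1.01 log units; beyond the scatter). For the measured compounds named here, that single step exchanges phenyl for vinyl on a saturated chain carbon bound to a nitrogen on an aromatic ring, and it is the only measured step.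

Compound 3 `CCN(CC)c1n[n+]([O-])c2ccccc2[n+]1[O-]` is not yet measured. It differs from compound 1 by diethylamino in place of allylamino on an aromatic carbon. Going by the values given here, no measured step touches this change: the step from compound 1 to compound 2 alters the chain end, whereas compound 3 alters the amino group itself, removing the donor and adding a second ethyl. Among the compounds with values here, the one known step therefore gives no direction for compound 3, and the default expectation is a number in the region of compound 1, with no step beyond the scatter in this assay.

For compound 3 the estimate in this assay is 22000 nM, with a range from 7000 nM to 70000 nM. This corresponds to an expected step of a 1.2-fold lower number from compound 1 to compound 3 (0.07 log units; within the scatter).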

Compound 3, half-maximal inhibitory concentration: > 49000 nM
Compound 3 gave a limit, no number (the forecaster's own chance of this, stated with the estimate: 15%); middle value at least 2.2-fold (0.34 log units) away from the limit.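

In this assay compound 3 gives a limit and no number, > 49000 nM. For the compounds shown here, the exchange of allylamino for diethylamino, on the aromatic carbon between two ring nitrogen atoms, is the first change at the amino group itself, and it gives an at least 1.8-fold higher number from compound 1 to compound 3 (0.27 log units; that floor lies within the scatter), so there is no sign of the lower number seen at the chain end with compound 2, while the true size of this step stays unfixed. The reading of this position therefore rests on a single open-ended value, and only its floor can be used: the limit of > 49000 nM in this assay, at which 1 of the 3 values shown sits.

The compounds shown do not separate the loss of the hydrogen-bond donor from the addition of the second ethyl, and a comparison with ethylamino on the same aromatic carbon would tell these two apart. Also open, going by these compounds, is how a ring amine such as morpholine behaves at this position, and whether the benzylamino of compound 2 keeps its number once a second group such as ethyl sits on the same nitrogen.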